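The compounds below may be only part of what the source reports. "The series", "measured", "known", "first", "only" and "open" are said of these compounds alone.

Compound 1 `COC[C@@H](C(C)C)C(c1ccc(O)c(OC)c1)c1ccc(O)c(OC)c1`: 54000 nM
Compound 2 `COc1cc(C(c2ccc(O)c(OC)c2)[C@@H](C)[C@H](C)CO)ccc1O`: > 100000 nM

On these data alone, compound 2 `COc1cc(C(c2ccc(O)c(OC)c2)[C@@H](C)[C@H](C)CO)ccc1O` reaches only a limit in a functional assay on HL-60 cells (Homo sapiens) for cytotoxicity, read by WST assay, with a stated time of 48 h (on this read-out lower numbers stand for stronger inhibition and higher numbers for weaker inhibition), reported as > 100000 nM, so its true number is unknown. Compound 1 `COC[C@@H](C(C)C)C(c1ccc(O)c(OC)c1)c1ccc(O)c(OC)c1` gives 54000 nM. Within the data shown here, the single measured step, an at least 1.8-fold higher number from compound 1 to compound 2 (0.26 log units; that floor lies within the scatter), ends at that limit (the limit of > 100000 nM in this assay, at which 1 of the 2 values shown sits). Compound 3 `COc1cc(C(c2ccc(O)c(OC)c2)[C@H](C)[C@H](C)CF)ccc1O` differs from compound 2 as 2-(fluoromethyl)-1-methylpropyl in place of 2-(hydroxymethyl)-1-methylpropyl on a saturated chain carbon bound to two aromatic carbons. Among the measured compounds shown here, no measured step involves a fluoromethyl group, so the direction of this change is open. The step expected for compound 3 is an at least 1.2-fold lower number from compound 2 to compound 3 (0.09 log units; that floor lies within the scatter). Compound 3 is estimated near 80000 nM, within 30000 nM to 250000 nM, with a real chance that only a limit is reported again.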

Compound 3, half-maximal inhibitory concentration: 56000 nM
The estimate for compound 3 lay 1.4-fold (0.15 log units) above the measured number; low and high end bracket the measured number.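

In this assay, the 2-(fluoromethyl)-1-methylpropyl chain gives a true number, with an at least 1.7-fold lower number from compound 2 to compound 3 (0.25 log units; that floor lies within the scatter) for its swap with the 2-(hydroxymethyl)-1-methylpropyl chain, so this position can yield a readable value. Compound 2 remains a limit at > 100000 nM and not a number. The fluoromethyl chain and the 1-(methoxymethyl)-2-methylpropyl chain read alike, with a 1.0-fold higher number from compound 1 to compound 3 (0.02 log units; within the scatter) on this carbon.

On these data alone, whether compound 2 truly differs from compound 3 stays open. So does how an amine, a carboxylic acid or a longer chain would read at this position.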